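Acyl chain length on the shared core

The source may hold more compounds than are shown below. What is called first, only, known or untested is meant among the compounds shown, and "the series" means these compounds.

Compound 1 `C[C@H]1C[C@H]1C(=O)N1CC2CNCC2C1` gives 10000 nM in an assay on CHO cells for agonist activity at Neuronal acetylcholine receptor; alpha3/beta4 (Homo sapiens), read by FLIPR and calcium flux; on this read-out lower numbers stand for an effect already at smaller amounts and higher numbers for an effect only at larger amounts of compound. Among the measured compounds shown here, compound 2 `CC(=O)N1CC2CNCC2C1` gives 23000 nM in this assay, the highest of the two numbers so far; the step from compound 1 to compound 2 is a 2.3-fold higher number from compound 1 to compound 2 (0.36 log units; beyond the scatter). Compound 3 `CCC(=O)N1CC2CNCC2C1` differs from compound 2 by methyl in place of hydrogen on a saturated chain carbon bound to a carbonyl carbon. This partly reverses the shortening seen in a 2.3-fold higher number from compound 1 to compound 2 (0.36 log units; beyond the scatter), so a modest lowering of the number is expected, within or just beyond the scatter, as a 1.4-fold lower number from compound 2 to compound 3 (0.16 log units; within the scatter). Compound 3 is therefore estimated at 16000 nM, with a range from 8000 nM to 35000 nM.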

Compound 3, half-maximal effective concentration: 18000 nM
Compound 3: the middle estimate sits 1.1-fold (0.05 log units) below what was measured; low and high end bracket the measured number.
By their numbers in this assay, from the lowest: compounds 1, 3 and 2 (each within the scatter of the next, the first and the last beyond it).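

Methyl in place of hydrogen on a saturated chain carbon bound to a carbonyl carbon, acetyl to propanoyl, gives in this assay a small step (a 1.3-fold lower number from compound 2 to compound 3 (0.11 log units; within the scatter)), so this change does not separate the two compounds. The remaining step also stays small (a 1.8-fold higher number from compound 1 to compound 3 (0.26 log units; within the scatter)), which places compound 3 within the scatter of both neighbours. No measured data bear on the reason for these numbers. Going by these compounds, whether a longer chain such as butanoyl, or an amine on the acyl chain, would move the number beyond the scatter of compound 3 stays open.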